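Compound 3 after two compounds at the limit

The source may hold more compounds than are shown below. What is called first, only, known or untested is meant among the compounds shown, and "the series" means these compounds.

Measured in a functional assay on A-375 cells (Homo sapiens) for inhibition, read by sulforhodamine B assay, with a stated time of 6 days; on this read-out higher numbers stand for weaker inhibition and lower numbers for stronger inhibition:
Compound 1 `CNCCNCc1cccc(-c2nc(NC3CCOCC3)c(C)c(-c3cn(C)nc3C)n2)c1`: > 50000 nM, a limit
Compound 2 `CNCCNCc1cccc(-c2nc(NC3CCOCC3)c(C)c(-c3c(C)nn(C)c3C)n2)c1`: > 50000 nM, a limit

Compound 2 gives only a limit, > 50000 nM, and no number. Compound 1 and compound 2 both rest at the limit of > 50000 nM in this assay, at which 2 of the 2 values shown sit. Compound 3 `CNCCNCc1cccc(-c2nc(NC3CCOCC3)c(C)c(-c3cccnc3)n2)c1` differs from compound 2 by one change, (pyridin-3-yl in place of 1,3,5-trimethyl-1H-pyrazol-4-yl on an aromatic carbon), pyridin-3-yl in place of 1,3,5-trimethyl-1H-pyrazol-4-yl on an aromatic carbon. Among the compounds with values here, the only measured step that bears on it is a step that the two limits leave unreadable from compound 1 to compound 2, so it offers no size to carry over. No step beyond the scatter is therefore expected in this assay. The estimated step is an at least 1.2-fold lower number from compound 2 to compound 3 (0.09 log units; that floor lies within the scatter). For compound 3 the estimate is 40000 nM, with an expected range of 12000 nM to 50000 nM.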

Compound 3, half-maximal inhibitory concentration: 45500 nM
For compound 3 the middle estimate is 1.1-fold (0.06 log units) below the measured one; low and high end bracket the measured number.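

In this assay compound 3, with pyridin-3-yl at the position ortho to a methyl group, gives a readable number, 45500 nM. Compound 1 and compound 2 gave only limits. The change amounts to an at least 1.0-fold lower number from compound 2 to compound 3 (0.04 log units; that floor lies within the scatter), and to an at least 1.0-fold lower number from compound 1 to compound 3 (0.04 log units; that floor lies within the scatter), so neither pair shows a step beyond the scatter. The comparison stays bounded on one side only: the limit of > 50000 nM in this assay, at which 2 of the 3 values shown sit.

As far as these compounds go, whether a phenyl or a pyridin-4-yl group at this position would give a step beyond the scatter remains open.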